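Trimming the amine substituent of compound 3

The compounds below may be only part of what the source reports. "The series", "measured", "known", "first", "only" and "open" are said of these compounds alone.

Compound 3 `COc1ccc(/C=C\c2cc(OC)c(OC)c(OC)c2)cc1OCc1ccc(CN[C@H](C(=O)O)[C@@H](C)O)cc1` stands apart from the other two compounds measured here. In a functional assay on HepG2 cells (Homo sapiens) for antiproliferative activity, read by CCK-8 assay, with a stated time of 48 h (a higher number here means a weaker inhibitor, a lower number a stronger inhibitor), compound 3 gives > 10000 nM, which is a limit of the assay and not a number. Compound 1 `COc1ccc(/C=C\c2cc(OC)c(OC)c(OC)c2)cc1OCc1ccc(CN2CCCCC2C(=O)O)cc1` gives 3100 nM and compound 2 `COc1ccc(/C=C\c2cc(OC)c(OC)c(OC)c2)cc1OCc1ccc(CN2CC[C@@H](C(=O)O)C2)cc1` gives 2300 nM, and both steps toward compound 3, an at least 3.2-fold higher number from compound 1 to compound 3 (0.50 log units; beyond the scatter) and an at least 4.3-fold higher number from compound 2 to compound 3 (0.63 log units; beyond the scatter), run beyond the scatter. Compound 4 `COc1ccc(/C=C\c2cc(OC)c(OC)c(OC)c2)cc1OCc1ccc(CNCCO)cc1` keeps the shared core and alters only the amine substituent: 2-hydroxyethyl in place of 1-carboxy-2-hydroxypropyl on an amine nitrogen. Going by the values given here, no measured step covers this change, and because compound 3 sits at the limit of > 10000 nM in this assay, at which 1 of the 3 values shown sits, the size of the step to compound 4 cannot be read from the data. Compound 4 is expected to show an at least 1.4-fold lower number from compound 3 to compound 4 (0.15 log units; that floor lies within the scatter), estimated at 7000 nM with a range from 1500 nM to 30000 nM.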

Compound 4, half-maximal inhibitory concentration: 5900 nM
Beside the measured number, compound 4's estimate is 1.2-fold (0.07 log units) above it; the range from low to high includes it.
By their numbers in this assay, from the lowest: compounds 2, 1 and 4 (each within the scatter of the next, the first and the last beyond it). At a limit, above all of these: compound 3.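

With 2-hydroxyethyl on the amine nitrogen, an open-chain substituent now gives a measured number in this assay, and the change from 1-carboxy-2-hydroxypropyl reads as an at least 1.6-fold lower number from compound 3 to compound 4 (0.22 log units; that floor lies within the scatter). Against the cyclic substituents the picture is uneven: 3-carboxypyrrolidin-1-yl gives way with a 2.6-fold higher number from compound 2 to compound 4 (0.41 log units; beyond the scatter), while 2-carboxypiperidin-1-yl gives way with a 1.9-fold higher number from compound 1 to compound 4 (0.28 log units; within the scatter). The true size of the first step stays unknown because the value of compound 3 is a limit: the limit of > 10000 nM in this assay, at which 1 of the 4 values shown sits.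

The compounds shown leave open how a longer hydroxyalkyl chain or a methoxyethyl group on this nitrogen would read. They also leave open what a simple carboxymethyl group would give.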